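The source may hold more compounds than are shown below. What is called first, only, known or untested is meant among the compounds shown, and "the series" means these compounds.

In a functional assay on RAW264.7 cells (Mus musculus), with a stated time of 24 h (on this read-out lower numbers stand for stronger inhibition and higher numbers for weaker inhibition), compound 3 (`COc1cc(OC)c2ccc(=O)oc2c1CC(C)(C)C=O`) gives 12400 nM and stands level with compound 1 (`COc1cc(OC)c2ccc(=O)oc2c1CC(C)(C)C(=O)O`), which gives 12400 nM on the same read-out. Together these two hold the lowest number of the three measured so far. Compound 2 (`C=C(C)C(O)C(OCC)c1c(OC)ccc2ccc(=O)oc12`) gives 43300 nM and so reads a higher number, beyond the scatter. Compound 4 (`CCOC(C)(C)C(O)Cc1c(OC)cc(OC)c2ccc(=O)oc12`) differs from compound 3 in one place (2-ethoxy-1-hydroxy-2-methylpropyl in place of 1-formyl-1-methylethyl on a saturated chain carbon bound to an aromatic carbon), on a saturated chain carbon bound to an aromatic carbon. Within the data shown here, the one measured step that bears on this change is no change at the digits printed from compound 1 to compound 3 (within the scatter) and it concerns only the group on a carbonyl carbon, so it leaves the larger replacement uncovered. Compound 2 also carries a hydroxy and an ethoxy group on its chain, but it differs from compound 3 in more than one place. At 43300 nM compound 2 therefore offers only a loose hint, and that hint points towards weaker inhibition. An estimated step of a 1.9-fold higher number from compound 3 to compound 4 (0.29 log units; within the scatter) is therefore expected in this assay in that direction, with wide uncertainty. For compound 4 the estimated value is 24000 nM with an expected range of 10000 nM to 55000 nM on that read-out.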

Compound 4, half-maximal inhibitory concentration: 31900 nM
Compound 4: the middle estimate sits 1.3-fold (0.12 log units) below what was measured; the range from low to high includes it.
By their numbers in this assay, from the lowest: compounds 1 and 3 (each within the scatter of the next); then compounds 4 and 2 (each within the scatter of the next).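

In this assay, the step of no change at the digits printed from compound 1 to compound 3 (within the scatter) had shown only that exchanging the group on the carbonyl carbon left the number unmoved, so it said nothing about a larger replacement on a saturated chain carbon bound to an aromatic carbon. The new compound shows that this place does respond to such a replacement: putting 2-ethoxy-1-hydroxy-2-methylpropyl in place of 1-formyl-1-methylethyl gives a 2.6-fold higher number from compound 3 to compound 4 (0.41 log units; beyond the scatter) and putting it in place of 1-carboxy-1-methylethyl gives a 2.6-fold higher number from compound 1 to compound 4 (0.41 log units; beyond the scatter) in the direction of weaker inhibition, so the larger group with its added hydroxy and ethoxy is tolerated with a modest loss and no more. Nothing measured here gives a cause for this loss.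

The hydroxy and the ethoxy enter together with a longer branched group, so the compounds shown do not separate what each contributes to the step. As far as these compounds go, how an amine or an amide at the end of the same chain would read in this assay also stays open.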